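The source may report more compounds than this note shows. Statements on the series, on what has been measured and on what is new or still open speak of the compounds shown alone.

Going by the values given here, compound 2 `COc1ccc(COC(=O)[C@H](CSCC2CCCCC2)NC(=O)CC(C)C)cc1` gives 1200 nM in an assay on IMR-32 cells for inhibition of Voltage-dependent N-type calcium channel subunit alpha-1B (Homo sapiens) (on this read-out higher numbers stand for weaker inhibition and lower numbers for stronger inhibition), the lower of the two numbers so far. Compound 1 `COc1ccc(COC(=O)[C@H](CSCC2CCCCC2)NC(=O)[C@@H]2CSCN2)cc1` gives 2700 nM in this assay, and the step of a 2.3-fold lower number from compound 1 to compound 2 (0.35 log units; beyond the scatter) is the only one yet recorded. Compound 3 `COc1ccc(COC(=O)[C@H](CSCC2CCCCC2)NC(=O)C2CCCC2)cc1` differs from compound 2 by cyclopentyl in place of isobutyl on a carbonyl carbon. Among the compounds with values here, no measured step swaps one such group for another, so the recorded step offers only loose guidance. Compound 3 is therefore expected to land close to compound 2, with the step of no change at the digits printed from compound 2 to compound 3 (within the scatter) not beyond the scatter. In this assay compound 3 is estimated at 1200 nM, with a range from 600 nM to 2400 nM.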

Compound 3, half-maximal inhibitory concentration: 920 nM
Beside the measured number, compound 3's estimate is 1.3-fold (0.12 log units) above it, within the range that was stated.
By their numbers in this assay, from the lowest: compounds 3 and 2 (each within the scatter of the next); then compound 1.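

Putting cyclopentyl in place of isobutyl on this carbonyl carbon gives a 1.3-fold lower number from compound 2 to compound 3 (0.12 log units; within the scatter), so in this assay the ring of carbon only and the open isobutyl group cannot be told apart here. Set against 1,3-thiazolidin-4-yl, cyclopentyl gives a 2.9-fold lower number from compound 1 to compound 3 (0.47 log units; beyond the scatter), so both groups made of carbon alone now stand beyond the scatter from compound 1. No evidence bears on the reason for these differences. Still open, on these data alone, is how a longer chain, a cyclohexyl ring or an amine on this carbonyl carbon would compare.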